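This account rests on a few compounds, and the source may have more. Where it says the series, first, only, none or still open, it means among the compounds named here.

Four compounds share one core, which is linked through a chain to an aromatic ring at the far end. Compound 1 `COC1=C(C)C(=O)/C(=C(O)/C=C/c2ccccc2OC)C(=O)C1(C)C` carries a methoxyphenyl ring there, and in a functional assay on 1A9 cells (Homo sapiens) for cytotoxicity (a lower number here means that less compound is needed, a higher number that more compound is needed for the effect), compound 1 gives 2.5 ug/mL. In this assay compound 2 `COC1=C(C)C(=O)/C(=C(O)/C=C/c2ccccc2C)C(=O)C1(C)C` gives "not determined" (no result reported), and compound 3 `COC1=C(C)C(=O)/C(=C(O)/C=C/c2cc(C)cc(C)c2)C(=O)C1(C)C` gives "not determined" (no result reported), so for compound 3 no number is known, and compound 2 likewise has no result, leaving compound 1 as the only measured point.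

Compound 4 `COC1=C(C)C(=O)/C(=C(O)/C=C/c2nccs2)C(=O)C1(C)C` differs from compound 3 by a single exchange at the end of the chain: 1,3-thiazol-2-yl in place of 3,5-dimethylphenyl on a double-bonded chain carbon bound to a double-bonded chain carbon.

Within the data shown here, since no measured pair in the set shows what such an exchange does, the direction of the step in this assay from compound 3 to compound 4 cannot be read off; a modest step, possibly toward more compound being needed, seems most plausible, but a change within the scatter would not be surprising. On that basis compound 4 is expected to give about 4 ug/mL in this assay, within a range from 1.5 ug/mL to 12 ug/mL.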

Compound 4, concentration for half-maximal effect: 3.5 ug/mL
Compound 4: the middle estimate sits 1.1-fold (0.06 log units) above what was measured; low and high end bracket the measured number.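

In this assay, putting 1,3-thiazol-2-yl in place of 2-methoxyphenyl on a double-bonded chain carbon bound to a double-bonded chain carbon gives a 1.4-fold higher number from compound 1 to compound 4 (0.15 log units; within the scatter), so the two compounds cannot be told apart. Among these compounds, this is the first readable comparison at this position, and it shows that a five-membered aromatic ring with 2 hetero atoms, one nitrogen and one sulfur, can stand at the end of the chain with the read-out staying within the usual scatter of the value for the benzene-ring compound. Steps involving compound 2 or compound 3 cannot be read, as neither has a reported number, and no supporting data are available to explain the result.

A single readable pair cannot say whether the end of the chain needs an aromatic ring at all, so an amine, a carboxylic acid or a plain alkyl chain in that place remains an open case. On these data alone, it also remains open how an unsubstituted phenyl ring or a pyridine ring would compare with compound 1 and compound 4.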